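Nitro in place of chloro: compound 4 from compound 2

A few compounds are considered here, and "the series" means these few. Any claim that something is new, unique, unknown or untested is made for them only; others in the source may bear on it.

Compound 1 `COc1cc(C(=O)c2sc(-c3cccs3)cc2N)cc(OC)c1OC` gives 9.8 nM in a functional assay on L1210 cells (Mus musculus) for antiproliferative activity; a lower number here means a stronger inhibitor, a higher number a weaker inhibitor. Compound 2 `COc1cc(C(=O)c2sc(-c3ccc(Cl)cc3)cc2N)cc(OC)c1OC` gives 93 nM, the second highest of the three numbers, and compound 3 `CCOc1ccc(-c2cc(N)c(C(=O)c3cc(OC)c(OC)c(OC)c3)s2)cc1` gives 590 nM. Compound 4 `COc1cc(C(=O)c2sc(-c3ccc([N+](=O)[O-])cc3)cc2N)cc(OC)c1OC` is not yet measured; it differs from compound 2 by nitro in place of chloro on an aromatic carbon. Among the measured compounds shown here, the one measured step at the same position, a 6.3-fold higher number from compound 2 to compound 3 (0.80 log units; beyond the scatter), was modest, and a 9.5-fold higher number from compound 1 to compound 2 (0.98 log units; beyond the scatter) shows that the aryl group itself matters. For the measured compounds named here, no measured compound carries a nitro, so the direction for compound 4 is open; a step of roughly the size of a 6.3-fold higher number from compound 2 to compound 3 (0.80 log units; beyond the scatter) in either direction would not surprise. A modest weakening is expected, a 1.6-fold higher number from compound 2 to compound 4 (0.21 log units; within the scatter). Compound 4 is therefore estimated at 150 nM, with a range of 40 nM to 600 nM.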

Compound 4, half-maximal inhibitory concentration: 100 nM
Beside the measured number, compound 4's estimate is 1.5-fold (0.18 log units) above it, and the stated range covers the measured number.
By their numbers in this assay, from the lowest: compound 1; then compounds 2 and 4 (each within the scatter of the next); then compound 3.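

In this assay nitro and chloro on this aromatic carbon give numbers that cannot be told apart (a 1.1-fold higher number from compound 2 to compound 4 (0.03 log units; within the scatter)), even though nitro brings hydrogen-bond acceptors and chloro brings none. Ethoxy is separated from nitro as well as from chloro (a 5.9-fold lower number from compound 3 to compound 4 (0.77 log units; beyond the scatter)), so the weak number of compound 3 belongs to ethoxy alone among these 4-substituents. The 4-nitrophenyl group, like 4-chlorophenyl, falls short of thiophen-2-yl (a 10-fold higher number from compound 1 to compound 4 (1.01 log units; beyond the scatter)).

No measurement shown accounts for these steps. As far as these compounds go, an amine, a carboxylic acid or a chain longer than ethoxy at this place remains open.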